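Series notes: compound 4, the methoxy analogue of compound 3

The source may hold more compounds than are shown below. What is called first, only, known or untested is meant among the compounds shown, and "the series" means these compounds.

The three measured compounds share a core and differ only in the attached aromatic group named in the steps below. Compound 1 `Nc1nc(N)c2c(-c3cc4ccccc4o3)cn([C@@H]3O[C@H](CO)[C@@H](O)[C@H]3O)c2n1` in a functional assay on K562 cells (Homo sapiens), read by MTT assay, with a stated time of 72 h (a higher number here means a weaker inhibitor, a lower number a stronger inhibitor), gives 18600 nM. Compound 2 `Nc1nc(N)c2c(-c3ccoc3)cn([C@@H]3O[C@H](CO)[C@@H](O)[C@H]3O)c2n1` in this assay reaches only > 20000 nM, a limit of the assay and not a number. Compound 3 `Nc1nc(N)c2c(-c3ccco3)cn([C@@H]3O[C@H](CO)[C@@H](O)[C@H]3O)c2n1` in this assay likewise reaches only > 20000 nM, again a limit of the assay. Compound 3 therefore stands at the limit, where two of the three values sit (the limit of > 20000 nM in this assay, at which 2 of the 3 values shown sit). The measured steps are an at least 1.0-fold higher number from compound 1 to compound 2 (0.03 log units; that floor lies within the scatter) and an at least 1.0-fold higher number from compound 1 to compound 3 (0.03 log units; that floor lies within the scatter), both with floors within the scatter, while a step that the two limits leave unreadable from compound 2 to compound 3.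

Compound 4 `COc1nc(N)nc2c1c(-c1ccco1)cn2[C@@H]1O[C@H](CO)[C@@H](O)[C@H]1O` differs from compound 3 in one place: methoxy in place of amino on an aromatic carbon. Within the data shown here, none of the measured steps touches the amino group; all concern the aromatic group, so none bears directly on this change. With compound 3 at the limit, no step beyond the scatter can be read, and the plain expectation is that compound 4 remains at the limit as well. Compound 4 is expected to give 30000 nM in this assay, with a range of 12000 nM to 80000 nM. The step that the limit leaves unreadable from compound 3 to compound 4 is thus estimated to lie within the scatter.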

Compound 4, half-maximal inhibitory concentration: > 20000 nM
Compound 4 ended at the assay's limit (the forecaster's own chance of this, stated with the estimate: 80%); the middle value is on the limit's open side.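

Compound 3 and compound 4 both sit at a limit in this assay and not at a number, so no step between them can be read: the limit of > 20000 nM in this assay, at which 3 of the 4 values shown sit.

The compounds shown leave open whether methoxy in place of amino on an aromatic carbon shifts the number in this assay at all.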